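The compounds below may be only part of what the source reports. "The series", "measured", "known", "first", "only" and "open" are said of these compounds alone.

Compounds measured:
- Compound 1 `CC(=O)OC[C@H]1O[C@@H](CC(=O)CC2(O)C(=O)N(Cc3ccc(F)cc3)c3ccccc32)[C@H](OC(C)=O)[C@@H](OC(C)=O)[C@@H]1OC(C)=O`: in an ADME assay on Vero cells (Chlorocebus sabaeus) for cytotoxicity, read by resazurin assay, with a stated time of 72 h (on this read-out lower numbers stand for higher toxicity in this test and higher numbers for lower toxicity in this test), compound 1 gives "not determined" (no result reported)
- Compound 2 `CC(=O)OC[C@H]1O[C@@H](CC(=O)CC2(O)C(=O)N(Cc3cccc(C)c3)c3ccccc32)[C@H](OC(C)=O)[C@@H](OC(C)=O)[C@@H]1OC(C)=O`: in this assay compound 2 gives "not determined" (no result reported)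
- Compound 3 `CCCCN1C(=O)/C(=C\C(=O)C[C@@H]2O[C@H](COC(C)=O)[C@@H](OC(C)=O)[C@H](OC(C)=O)[C@H]2OC(C)=O)c2ccccc21`: in this assay compound 3 gives 126000 nM

Within the data shown here, compound 3 is the only member of this small set with a number in this assay; compound 1 and compound 2 carry no result there, so compound 3 cannot be placed against any neighbour, and its value simply stands on its own. The account now follows the step from compound 3 to compound 4 `CC(=O)OC[C@H]1O[C@@H](CC(=O)/C=C2\C(=O)N(Cc3cccc(C)c3)c3ccccc32)[C@H](OC(C)=O)[C@@H](OC(C)=O)[C@@H]1OC(C)=O`, which is not yet measured in this assay. The change is 3-methylphenyl in place of propyl on a saturated chain carbon bound to an amide-type nitrogen in a ring. Among the measured compounds shown here, no measured pair in the set differs in only this one place, so there is no step on record to lean on. For the measured compounds named here, with no comparison available, the expectation rests on the single value of compound 3 alone. For compound 4 the step from compound 3 is expected to be a 1.6-fold lower number from compound 3 to compound 4 (0.20 log units; within the scatter), a move toward a lower number that may well stay within the scatter of repeated measurements. Compound 4 is therefore estimated to give 80000 nM in this assay, with a range from 30000 nM to 200000 nM.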

Compound 4, half-maximal cytotoxic concentration: 72500 nM
Compound 4: the middle estimate sits 1.1-fold (0.04 log units) above what was measured, and the stated range covers the measured number.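

In this assay, among these compounds, the step of a 1.7-fold lower number from compound 3 to compound 4 (0.24 log units; within the scatter) is the first reading on record at this position, and it shows that 3-methylphenyl in place of propyl on a saturated chain carbon bound to an amide-type nitrogen in a ring gives no difference that can be separated from repeat measurement. Cut one bond further out, the same change reads butyl to 3-methylbenzyl, so this position carries either a plain chain or a group with a six-membered aromatic ring with no separable difference in this read-out. This rests on one pair alone and makes no claim for any other group at this position. Nothing available here explains this outcome.

Among the compounds shown here, compound 1 and compound 2 carry no result in this assay, so no steps involving them can be read. On these data alone, it also remains open how this position would respond to an amine, a carboxylic acid or a longer chain such as octyl in place of the groups seen here.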